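A few compounds are considered here, and "the series" means these few. Any claim that something is new, unique, unknown or untested is made for them only; others in the source may bear on it.

Within the data shown here, compound 1 `COC(=O)c1cc(OCC(=O)[C@H](CC(=O)O)NC(=O)[C@@H](NC(=O)COc2cccc3ccccc23)C(C)C)no1` is the only member with a readable number: in a functional assay on Jurkat cells (Homo sapiens) for inhibition (a higher number here means a weaker inhibitor, a lower number a stronger inhibitor), compound 1 gives 71000 nM. Compound 2 `CC(C)[C@H](NC(=O)COc1cccc2ccccc12)C(=O)N[C@@H](CC(=O)O)C(=O)CSc1nccn1C` reaches only a limit, compound 2 giving > 200000 nM in this assay. Compound 3 `CC(C)[C@H](NC(=O)COc1cccc2ccccc12)C(=O)N[C@@H](CC(=O)O)C(=O)CSc1nncn1C` likewise reaches only a limit, compound 3 giving > 200000 nM in this assay. Exchanging the (5-(methoxycarbonyl)-1,2-oxazol-3-yl)oxy group for a sulfur-linked five-membered ring gives an at least 2.8-fold higher number from compound 1 to compound 2 (0.44 log units; beyond the scatter) and an at least 2.8-fold higher number from compound 1 to compound 3 (0.44 log units; beyond the scatter); the swap between the two sulfur-linked rings gives a step that the two limits leave unreadable from compound 2 to compound 3, resting on (the limit of > 200000 nM in this assay, at which 2 of the 3 values shown sit).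

Compound 4 `Cc1nnc(SCC(=O)[C@H](CC(=O)O)NC(=O)[C@@H](NC(=O)COc2cccc3ccccc23)C(C)C)s1` differs from compound 3 in one place: 5-methyl-1,3,4-thiadiazol-2-yl in place of 4-methyl-4H-1,2,4-triazol-3-yl on a sulfur. Among the measured compounds shown here, the only step bearing on it is the unreadable ring swap on the sulfur, and both measured sulfur-linked rings sit at the limit. Compound 4 is therefore expected to stay at or beyond the limit, with a step that the limit leaves unreadable from compound 3 to compound 4. The estimate for compound 4 in this assay is 250000 nM, within 100000 nM to 600000 nM.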

Compound 4, half-maximal inhibitory concentration: 190000 nM
Compound 4: middle estimate off by 1.3-fold (0.12 log units), on the high side, within the range that was stated.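

Among these compounds, on the sulfur, 5-methyl-1,3,4-thiadiazol-2-yl gives the one readable number among the sulfur-linked rings: in this assay compound 4 gives 190000 nM. The ring swaps give an at least 1.0-fold lower number from compound 3 to compound 4 (0.02 log units; that floor lies within the scatter) and an at least 1.0-fold lower number from compound 2 to compound 4 (0.02 log units; that floor lies within the scatter), so no order among the three rings can be read. Among the compounds shown here, the exchange of the oxygen-linked group now has a measured size, a 2.7-fold higher number from compound 1 to compound 4 (0.43 log units; beyond the scatter), where the earlier steps gave only bounds.

Going by these compounds, whether the linking sulfur or the ring sets this step stays open. A (5-methyl-1,3,4-thiadiazol-2-yl)oxy group or a plain phenoxy group on the saturated chain carbon would separate the two.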